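Methyl for Chloro on the Other Outer Ring

A few compounds are considered here, and "the series" means these few. Any claim that something is new, unique, unknown or untested is made for them only; others in the source may bear on it.

Compound 1 `CCOC(=O)c1c(-c2ccc(Cl)cc2)cc(-c2ccccc2)nc1Nc1ccc(C)cc1`: 61.8%
Compound 2 `CCOC(=O)c1c(-c2ccc(Cl)cc2)cc(-c2ccccc2)nc1Nc1ccc(OC)cc1`: 38.9%
Compound 3 `CCOC(=O)c1c(-c2ccc(Cl)cc2)cc(-c2ccccc2)nc1Nc1ccc(Cl)cc1`: 65.2%

These three share one core and differ only in a single group on one outer ring, all measured in a functional assay on the whole organism (strain Wister albino) for inhibition, with Rattus norvegicus as the target, read by paw edema, with stated times of 1 h and 4 h, at a dose of 50 mg/kg by the intraperitoneal route; on this read-out lower numbers stand for less inhibition and higher numbers for more inhibition at the one dose given (going by the name of the read-out). Compound 2 stands lowest of the three: a number 26.3 percentage points higher from compound 2 to compound 3 (beyond the scatter) and a number 22.9 percentage points lower from compound 1 to compound 2 (beyond the scatter) both lie beyond the scatter, whereas a number 3.4 percentage points higher from compound 1 to compound 3 (within the scatter) lies within it. Compound 4 `CCOC(=O)c1c(-c2ccc(C)cc2)cc(-c2ccccc2)nc1Nc1ccc(OC)cc1` keeps the methoxy of compound 2 and changes a different ring instead: methyl in place of chloro on an aromatic carbon, that is, 4-chlorophenyl to 4-methylphenyl. Within the data shown here, no measured step touches this ring. Among the measured compounds shown here, the only chloro-versus-methyl comparison available, a number 3.4 percentage points higher from compound 1 to compound 3 (within the scatter), sits on the other ring and stayed within the scatter. The expected step is therefore a number 1.1 percentage points higher from compound 2 to compound 4 (within the scatter), nothing beyond the scatter. Compound 4 is estimated at 40%, between 25% and 55%.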

Compound 4, a percentage reported as inhibition, in the whole organism at one dose (the size of the read-out at that dose, not a potency): 89.4%
The estimate for compound 4 lay 49.4 percentage points below the measured number; the measured number lies above the stated range.
By their numbers in this assay, from the lowest: compound 2; then compounds 1 and 3 (each within the scatter of the next); then compound 4.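

Among these compounds, this position, with no step measured on it until now, responds strongly to methyl in place of chloro, with a number 50.5 percentage points higher from compound 2 to compound 4 (beyond the scatter). A step read on one ring therefore says little about the same exchange on the other, as the two steps differ by far more than scatter: the same change on two cores in this assay, a number 3.4 percentage points higher (within the scatter) from compound 1 to compound 3 and a number 50.5 percentage points lower (beyond the scatter) from compound 4 to compound 2, 53.9 percentage points apart, beyond the scatter of two such steps

Open, from the compounds shown here alone, is whether a different group at this position, such as an amine or a carboxylic acid, would give a similar number. Also open, going by these compounds, is whether the rise holds when the other outer ring carries the methyl of compound 1 or the chloro of compound 3.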